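Aryloxy tail swap on a serine phosphodiester series

A few compounds are considered here, and "the series" means these few. Any claim that something is new, unique, unknown or untested is made for them only; others in the source may bear on it.

compound 1 `N[C@@H](COP(=O)(O)OCCCOC(=O)CCc1ccccc1OCCCCOc1ccccc1)C(=O)O`: 6.1%
compound 2 `Cc1cccc(Oc2cccc(COc3ccccc3CCC(=O)OCCCOP(=O)(O)OC[C@H](N)C(=O)O)c2)c1`: 21.3%

In an assay on cells for agonist activity at probable G-protein coupled receptor 34 (Mus musculus), with a stated time of 1 h (a lower number here means a smaller maximal response, a higher number a larger maximal response), compound 2 gives 21.3% and stands highest of the two numbers; compound 1 lies lower by a margin beyond the scatter. Compound 3 `N[C@@H](COP(=O)(O)OCCCOC(=O)CCc1ccccc1OCc1cccc(Oc2ccc(Br)cc2)c1)C(=O)O` differs from compound 2 only in 4-bromophenyl in place of 3-methylphenyl on an oxygen on an aromatic ring. For the measured compounds named here, no measured pair shows this change, so no step size is known for it. The step of a number 1.3 percentage points lower from compound 2 to compound 3 (within the scatter) is expected to stay within the usual scatter, with no clear direction. The maximal response of compound 3 is therefore estimated at 20%, with a range from 8% to 35%.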

Compound 3, largest response reached (Emax), in percent of the reference or control that the assay uses: 17.7%
The estimate for compound 3 lay 2.3 percentage points above the measured number; low and high end bracket the measured number.
By their numbers in this assay, from the lowest: compound 1; then compounds 3 and 2 (each within the scatter of the next).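

In this assay, 4-bromophenyl in place of 3-methylphenyl on an oxygen on an aromatic ring gives a number 3.6 percentage points lower from compound 2 to compound 3 (within the scatter), so this exchange of one aryl group for another leaves the maximal response unresolved from the scatter. For the compounds shown here, this single step is the first direct reading at this position, and it covers only these two groups. No available data explain the result.

Going by these compounds, whether an amine or a carboxylic acid in place of 4-bromophenyl on that oxygen would move the maximal response remains open.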